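Swapping fluoro for ethoxy on the shared core

A few compounds are considered here, and "the series" means these few. Any claim that something is new, unique, unknown or untested is made for them only; others in the source may bear on it.

Compound 1 `CCOc1ccc2nc(C(=O)Nc3c(F)cc(-c4cccc(F)c4)cc3F)c(C)c(O)c2c1` gives > 100000 nM (a limit)
Compound 2 `Cc1c(C(=O)Nc2c(F)cc(-c3cccc(F)c3)cc2F)nc2ccc(F)cc2c1C(=O)O` gives 14700 nM (a number)

In a functional assay on Hep 3B2 cells (Homo sapiens) for antiproliferative activity, read by MTT assay, with a stated time of 24 h (on this read-out lower numbers stand for stronger inhibition and higher numbers for weaker inhibition), compound 1 gives > 100000 nM as a limit of the assay, not a number. Among the compounds with values here, compound 2 gives 14700 nM as the only actual number so far. Compound 3 `CCOc1ccc2nc(C(=O)Nc3c(F)cc(-c4cccc(F)c4)cc3F)c(C)c(C(=O)O)c2c1` differs from compound 2 in one place, with ethoxy in place of fluoro on an aromatic carbon and the rest unchanged. Within the data shown here, no measured step guides this swap, so only a slight weakening, within the usual scatter, is expected in this assay for this pair. The estimated size of the change is a 1.4-fold higher number from compound 2 to compound 3 (0.13 log units; within the scatter) on this read-out. For compound 3 the estimate is 20000 nM with an expected range from 6000 nM to 70000 nM overall.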

Compound 3, half-maximal inhibitory concentration: 5800 nM
Beside the measured number, compound 3's estimate is 3.4-fold (0.54 log units) above it, outside the stated range (below it).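

In this assay, ethoxy in place of fluoro on this aromatic carbon gives a 2.5-fold lower number from compound 2 to compound 3 (0.40 log units; beyond the scatter), so this position takes ethoxy with stronger inhibition, not weaker. With ethoxy kept, carboxy in place of hydroxy on an aromatic carbon gives an at least 17-fold lower number from compound 1 to compound 3 (1.23 log units; beyond the scatter), the larger of the two steps. Compound 1 gives no actual number, only a limit: the limit of > 100000 nM in this assay, at which 1 of the 3 values shown sits.

The compounds shown leave open whether a longer chain, such as propoxy, or an amine at this position would lower the number further. They also leave open whether ethoxy gives the same step on other cores.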